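The source may hold more compounds than are shown below. What is called first, only, known or untested is meant among the compounds shown, and "the series" means these compounds.

Working notes on the series. In a functional assay on A549 cells (Homo sapiens) for cytotoxicity, read by MTT assay, with a stated time of 72 h (on this read-out lower numbers stand for stronger inhibition and higher numbers for weaker inhibition), compound 1 `CCN1C/C(=C\c2cc(OC)c(OC)c(OC)c2)C(=O)/C(=C/c2cc(OC)c(OC)c(OC)c2)C1` gives 4200 nM and compound 2 `COc1cc(/C=C2\CN(C(=O)CCC(=O)O)C/C(=C\c3cc(OC)c(OC)c(OC)c3)C2=O)cc(OC)c1OC` gives 17900 nM, so compound 2 carries the higher of the two numbers and the weaker inhibition of the pair. Compound 3 `COc1cc(/C=C2\CN(C(=O)C(C)C)C/C(=C\c3cc(OC)c(OC)c(OC)c3)C2=O)cc(OC)c1OC` has not yet been measured in this assay.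

The change from compound 2 to compound 3 is isopropyl in place of 2-carboxyethyl on a carbonyl carbon, whose other neighbour is an amide-type nitrogen in a ring. Among the compounds with values here, only one measured step bears on this: a 4.3-fold higher number from compound 1 to compound 2 (0.63 log units; beyond the scatter), a modest step beyond the scatter, with (2-carboxyethyl)carbonyl in place of ethyl on an amine nitrogen in a ring. Within the data shown here, the 2-carboxyethyl now leaves but the carbonyl stays, and no measured compound carries isopropylcarbonyl, so the reversal is only partial. A step toward lower numbers is therefore expected, somewhat smaller than the measured one and with a real chance of staying within the scatter. The expected move is a 2.2-fold lower number from compound 2 to compound 3 (0.35 log units; beyond the scatter). For compound 3 the estimate is 8000 nM, with an expected range of 3000 nM to 20000 nM.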

Compound 3, half-maximal inhibitory concentration: 800 nM
For compound 3 the middle estimate is 10-fold (1.00 log units) above the measured one, outside the stated range (below it).
By their numbers in this assay, from the lowest: compound 3; then compound 1; then compound 2.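

In this assay the step of a 22-fold lower number from compound 2 to compound 3 (1.35 log units; beyond the scatter) shows that the group on the carbonyl carbon, whose other neighbour is an amide-type nitrogen in a ring, has a large bearing on the read-out, so the carbonyl on the ring nitrogen does not by itself carry the higher number seen with compound 2. The step of a 5.3-fold lower number from compound 1 to compound 3 (0.72 log units; beyond the scatter) adds that replacing ethyl with isopropylcarbonyl goes toward lower numbers, while a 4.3-fold higher number from compound 1 to compound 2 (0.63 log units; beyond the scatter) goes the other way, so the direction of a change from ethyl at this nitrogen depends on what the carbonyl carries, and among the compounds shown compound 3 has the lowest number, with both of its steps beyond the scatter. Nothing available here gives a measured reason for either direction.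

Compounds 2 and 3 differ both in the carboxylic acid and in the chain, so the large step cannot be assigned to either one alone. A methyl ester of the same chain, or a plain propyl or a longer alkyl chain on the carbonyl carbon, would be needed to separate the two, and a terminal amine on that chain remains an open comparison with the carboxylic acid.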